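Removing the amine methyl: from compound 3 to compound 4

The source may hold more compounds than are shown below. What is called first, only, known or untested is meant among the compounds shown, and "the series" means these compounds.

Measured so far:
Compound 1 `O=S(=O)(NCCCNCc1cccc(Cl)c1)c1cc(C(F)(F)F)cc(C(F)(F)F)c1` gives 7000 nM in a toxicity assay on MCF-10A cells (Homo sapiens) for inhibition, read by MTT assay, with a stated time of 72 h; a higher number here means a weaker inhibitor of growth, a lower number a stronger inhibitor of growth.
Compound 2 `O=S(=O)(NCCCNCC1COc2ccccc2O1)c1cc(C(F)(F)F)cc(C(F)(F)F)c1` gives 3200 nM in this assay.
Compound 3 `CN(CCCNS(=O)(=O)c1cc(C(F)(F)F)cc(C(F)(F)F)c1)Cc1ccccc1` gives 26000 nM in this assay.

Compound 3 stands at the highest number of the three, i.e. the weakest inhibition of growth among them. Its nearest neighbour is compound 1, reached through a 3.7-fold higher number from compound 1 to compound 3 (0.57 log units; beyond the scatter); compound 2 lies further off, and the step of a 2.2-fold lower number from compound 1 to compound 2 (0.34 log units; beyond the scatter) concerns the ring on the chain carbon and does not touch the amine nitrogen.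

Compound 4 `O=S(=O)(NCCCNCc1ccccc1)c1cc(C(F)(F)F)cc(C(F)(F)F)c1` differs from compound 3 in one place: hydrogen in place of methyl on an amine nitrogen. Going by the values given here, no measured pair isolates this change. Among the compounds with values here, the only step that bears on it is a 3.7-fold higher number from compound 1 to compound 3 (0.57 log units; beyond the scatter), which combines the methyl on the amine nitrogen with a change of the benzyl group itself, so only part of that step can be credited to the methyl. Compound 4 keeps the plain benzyl of compound 3 and the amine hydrogen of compound 1, and so is expected to fall between the two.

The expected step is a 2.2-fold lower number from compound 3 to compound 4 (0.34 log units; beyond the scatter), a lower number, because a 3.7-fold higher number from compound 1 to compound 3 (0.57 log units; beyond the scatter) moved upward when the methyl entered. For compound 4 the estimate in this assay is 12000 nM, with a range of 5000 nM to 30000 nM.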

Compound 4, concentration for 50% growth inhibition: 13000 nM
Compound 4: the middle estimate sits 1.1-fold (0.03 log units) below what was measured; measured number inside the range.
By their numbers in this assay, from the lowest: compound 2; then compounds 1, 4 and 3 (each within the scatter of the next, the first and the last beyond it).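

In this assay, going by these compounds alone, the step for hydrogen in place of methyl on the amine nitrogen is a 2.0-fold lower number from compound 3 to compound 4 (0.30 log units; within the scatter) and, read alone for the first time, does not separate the two groups on this plain benzyl compound. With a 1.9-fold higher number from compound 1 to compound 4 (0.27 log units; within the scatter) for hydrogen in place of chloro on an aromatic carbon, the earlier 3.7-fold higher number from compound 1 to compound 3 (0.57 log units; beyond the scatter) now divides into two single changes that each stay within the scatter, although together they lie beyond it. The ring on the chain carbon remains a place with a step beyond the scatter, shown by a 4.1-fold higher number from compound 2 to compound 4 (0.61 log units; beyond the scatter) for phenyl in place of 2,3-dihydro-1,4-benzodioxin-2-yl on a saturated chain carbon bound to an amine nitrogen.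

Open, on these data alone, is whether an ethyl or an acetyl group on this amine nitrogen would give a step beyond the scatter, and whether a methyl there reads the same alongside the 3-chlorobenzyl or 2,3-dihydro-1,4-benzodioxin-2-yl groups. Nothing at hand accounts for any of these steps.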